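A few compounds are considered here, and "the series" means these few. Any claim that something is new, unique, unknown or untested is made for them only; others in the source may bear on it.

Compound 3 `CC(C)c1ccc(-c2nc(SCc3cn(CC(=O)NC(=O)Nc4ccccn4)nn3)nc(Nc3ccccc3)c2C#N)cc1` belongs to a small set sharing one core and differing in the group on the nitrogen attached to the aromatic ring. In a functional assay on MGC-803 cells (Homo sapiens) for inhibition, read by MTT assay, with a stated time of 72 h (a higher number here means a weaker inhibitor, a lower number a stronger inhibitor), compound 3 gives 15800 nM, the lowest of the two numbers shown, with compound 1 `CC(C)c1ccc(-c2nc(SCc3cn(CC(=O)NC(=O)Nc4ccccn4)nn3)nc(Nc3ccccc3Cl)c2C#N)cc1` nearest at 19700 nM. Compound 2 `CC(C)c1ccc(-c2nc(SCc3cn(CC(=O)NC(=O)Nc4ccccn4)nn3)nc(Nc3ccc(Cl)cc3)c2C#N)cc1` returns only a limit of the assay, > 64000 nM, so the limit of > 64000 nM in this assay, at which 1 of the 3 values shown sits, marks where it sits. The step of a 1.2-fold lower number from compound 1 to compound 3 (0.10 log units; within the scatter) shows that removing the chloro from compound 1 changes little, whereas an at least 3.2-fold higher number from compound 1 to compound 2 (0.51 log units; beyond the scatter) and an at least 4.0-fold lower number from compound 2 to compound 3 (0.60 log units; beyond the scatter) show a chloro on the 4-position of that ring weakens inhibition.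

Compound 4 `COc1ccccc1Nc1nc(SCc2cn(CC(=O)NC(=O)Nc3ccccn3)nn2)nc(-c2ccc(C(C)C)cc2)c1C#N` differs from compound 3 by methoxy in place of hydrogen on an aromatic carbon, that is, phenyl becomes 2-methoxyphenyl. Going by the values given here, the only step bearing on a group at this place is a 1.2-fold lower number from compound 1 to compound 3 (0.10 log units; within the scatter), which stayed within the scatter, so the expected step of a 1.1-fold higher number from compound 3 to compound 4 (0.03 log units; within the scatter) is likewise small. Compound 4 is therefore estimated at 17000 nM in this assay, with a range from 6000 nM to 48000 nM.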

Compound 4, half-maximal inhibitory concentration: > 64000 nM
Compound 4 gave a limit, no number (the forecaster's own chance of this, stated with the estimate: 12%); middle value at least 3.7-fold (0.57 log units) away from the limit.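

In this assay, a group ortho to a large group does not leave inhibition unchanged as a rule: methoxy in place of hydrogen gives an at least 4.0-fold higher number from compound 3 to compound 4 (0.60 log units; beyond the scatter), whereas chloro at this place stayed within the scatter of hydrogen. Methoxy in place of chloro gives an at least 3.2-fold higher number from compound 1 to compound 4 (0.51 log units; beyond the scatter), so the outcome at this place depends on which group enters and not merely on the place being filled. The value of compound 4 is a limit of the assay, as is that of compound 2, and the step between these two cannot be read: the limit of > 64000 nM in this assay, at which 2 of the 4 values shown sit.

As far as these compounds go, whether fluoro or methyl at this place would follow chloro or methoxy remains open, as does the outcome with hydroxy or an amine. From the compounds shown here alone, how far compound 4 truly lies from compound 3 also stays open.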